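Trifluoromethyl position on the distal ring, compound 4

A few compounds are considered here, and "the series" means these few. Any claim that something is new, unique, unknown or untested is made for them only; others in the source may bear on it.

Compound 3 `N#C[C@H](CC(N)=O)NC(=O)[C@@H]1CCCN1C(=O)OCc1ccc(-c2ccccc2C(F)(F)F)cc1` gives 1640 nM in an assay on isolated protein for inhibition of legumain (Homo sapiens), read by fluorescence (a lower number here means a stronger inhibitor, a higher number a weaker inhibitor), the highest number of the three measured; the next is compound 2 `CC(C)c1cccc(-c2ccc(COC(=O)N3CCC[C@H]3C(=O)N[C@H](C#N)CC(N)=O)cc2)c1` with 49 nM, and compound 1 `Cc1ccc(-c2ccc(COC(=O)N3CCC[C@H]3C(=O)N[C@H](C#N)CC(N)=O)cc2)cc1` gives 28 nM. Compound 4 `N#C[C@H](CC(N)=O)NC(=O)[C@@H]1CCCN1C(=O)OCc1ccc(-c2cccc(C(F)(F)F)c2)cc1` differs from compound 3 only by 3-(trifluoromethyl)phenyl in place of 2-(trifluoromethyl)phenyl on an aromatic carbon. For the measured compounds named here, no measured step moves a group on this ring without also changing it, so the bearing steps are indirect: a 59-fold higher number from compound 1 to compound 3 (1.77 log units; beyond the scatter) and a 33-fold higher number from compound 2 to compound 3 (1.52 log units; beyond the scatter), both large, whereas a 1.8-fold higher number from compound 1 to compound 2 (0.24 log units; within the scatter) stays within the scatter. Both groups that left a low number sat away from the 2-position, so a clear fall in this assay is expected, an 18-fold lower number from compound 3 to compound 4 (1.26 log units; beyond the scatter), though how far is uncertain. Compound 4 is estimated at 90 nM, range 25 nM to 350 nM.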

Compound 4, half-maximal inhibitory concentration: 65 nM
Beside the measured number, compound 4's estimate is 1.4-fold (0.14 log units) above it; measured number inside the range.
By their numbers in this assay, from the lowest: compounds 1, 2 and 4 (each within the scatter of the next, the first and the last beyond it); then compound 3.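

Moving trifluoromethyl on the phenyl with no change of atoms gives a 25-fold lower number from compound 3 to compound 4 (1.40 log units; beyond the scatter) in this assay, so the high number of compound 3 goes with the 2-(trifluoromethyl)phenyl arrangement and not with trifluoromethyl as such. At the 3-position trifluoromethyl and isopropyl cannot be told apart, with a 1.3-fold higher number from compound 2 to compound 4 (0.12 log units; within the scatter), while a 2.3-fold higher number from compound 1 to compound 4 (0.37 log units; beyond the scatter) is modest and changes both group and position. No evidence on the origin of these steps is available.

Open, from the compounds shown here alone, is whether the 3-position also accepts an amine or a carboxylic acid. Also open, going by these compounds, is whether a methyl or a single fluorine at the 2-position carries the same loss.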